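The source may hold more compounds than are shown below. What is called first, only, known or untested is meant among the compounds shown, and "the series" means these compounds.

In an ADME assay on microsomes from liver (Homo sapiens) for metabolic stability (a higher number here means that the compound lasts longer, a lower number that the compound disappears faster), compound 1 (`CC#C[C@@H](Cc1nnn[nH]1)c1ccc(OCc2ccc3scc(-c4cccnc4C)c3c2)cc1`) gives < 0.0667 h, which is a limit of the assay and not a number. Its true half-life is therefore unknown. Two relatives offer some context: compound 2 (`CC#C[C@@H](Cc1nnn[nH]1)c1ccc(OCc2ccc3sc(F)c(-c4ccccc4C)c3c2)cc1`) gives 0.0667 h, and compound 3 (`CC#C[C@@H](Cc1nnn[nH]1)c1ccc(OCc2cc(F)c3scc(-c4ccc(OC)cc4C)c3c2)cc1`) gives 0.5 h. Both differ from compound 1 in more than one place, so neither value isolates the effect of a single change.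

Compound 4 (`CC#C[C@@H](Cc1nnn[nH]1)c1ccc(OCc2ccc3scc(-c4cncnc4C)c3c2)cc1`) has not yet been measured. It carries 4-methylpyrimidin-5-yl in place of 2-methylpyridin-3-yl, on an aromatic carbon of a five-membered aromatic ring with 1 sulfur (4-methylpyrimidin-5-yl in place of 2-methylpyridin-3-yl on an aromatic carbon). Among the measured compounds shown here, no measured pair shows this swap, so its size cannot be read directly from the data, and the expectation is a cautious one. The expected change, an at least 1.1-fold higher number from compound 1 to compound 4 (0.07 log units; that floor lies within the scatter), is a small rise that may not clear the usual scatter. For compound 4 the half-life in this assay is estimated at 0.08 h, with an expected range from 0.04 h to 0.25 h.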

Compound 4, half-life: 0.233 h
Estimate against measurement, compound 4: 2.9-fold (0.46 log units) below; the measured number falls inside the stated range.
By their numbers in this assay, from the lowest: compound 2; then compound 4; then compound 3.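

Among the compounds shown here, this is the first comparison in which only one place changes: on an aromatic carbon of the five-membered aromatic ring with 1 sulfur, 4-methylpyrimidin-5-yl in place of 2-methylpyridin-3-yl gives an at least 3.4-fold higher number from compound 1 to compound 4 (0.54 log units; beyond the scatter) in this assay. Both groups have 7 heavy atoms, and the entering group has 2 nitrogen atoms where the leaving group has 1, so this position responds to a change in the ring's atoms without any change in group size. The true size of the step remains unknown and only its lower bound can be read, because compound 1 stands at a limit of the assay and not at a number: the limit of < 0.0667 h in this assay, at which 1 of the 4 values shown sits.

From the compounds shown here alone, whether the same swap would raise the number in the fluorine-bearing compound 2 and compound 3 remains open. Also open, going by these compounds, is how this position would respond to a pyridine ring carrying an amine or a carboxylic acid.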